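This account rests on a few compounds, and the source may have more. Where it says the series, first, only, none or still open, it means among the compounds named here.

Measured so far in a functional assay on RS4-11 cells (Homo sapiens) for inhibition, read by CCK-8 assay, with a stated time of 48 h; a lower number here means a stronger inhibitor, a higher number a weaker inhibitor:
- Compound 1 `COc1ccc(NC(=O)NCCNS(=O)(=O)c2ccc(-c3ccccc3OCc3ccccc3)s2)cc1`: > 20000 nM (a limit)
- Compound 2 `O=[N+]([O-])c1ccc(NC(=S)NCCNS(=O)(=O)c2ccc(-c3ccccc3O[C@H]3CC[C@@H](O)CC3)s2)cc1`: 9400 nM
- Compound 3 `O=S(=O)(NCCNC(=S)Nc1cccc(Cl)c1)c1ccc(-c2ccccc2OCc2ccccc2)s1`: > 50000 nM (a limit)

Compound 3 has no exact number, only the limit > 50000 nM. Compound 4 `O=[N+]([O-])c1ccc(NC(=S)NCCNS(=O)(=O)c2ccc(-c3ccccc3OCc3ccccc3)s2)cc1` carries 4-nitrophenyl in place of 3-chlorophenyl on an amide-type nitrogen. For the measured compounds named here, the only measured step, a step that the two limits leave unreadable from compound 1 to compound 3, has no readable size to carry over. There is one guide, which also carries 4-nitrophenyl but differs from compound 4 elsewhere: compound 2 gives 9400 nM. A move towards stronger inhibition is therefore expected, though its size is uncertain. The expected change is an at least 5.0-fold lower number from compound 3 to compound 4 (0.69 log units; beyond the scatter). For compound 4 the estimate is 10000 nM, with an expected range of 2500 nM to 40000 nM.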

Compound 4, half-maximal inhibitory concentration: 11300 nM
Compound 4: the middle estimate sits 1.1-fold (0.05 log units) below what was measured; measured number inside the range.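

In this assay, 4-nitrophenyl on the amide-type nitrogen gives a real gain over 3-chlorophenyl (an at least 4.4-fold lower number from compound 3 to compound 4 (0.64 log units; beyond the scatter)), and this size is only a floor, resting on a limit. A second limit leaves a smaller floor that lies within the scatter (an at least 1.7-fold lower number from compound 1 to compound 4 (0.24 log units; that floor lies within the scatter)). With 4-nitrophenyl in place, benzyl and 4-hydroxycyclohexyl on the oxygen cannot be told apart (a 1.2-fold higher number from compound 2 to compound 4 (0.08 log units; within the scatter)).

On these data alone, whether other groups on this nitrogen, such as 4-aminophenyl or 4-carboxyphenyl, would go further stays open. So does what a carbonyl in place of the thiocarbonyl would do to compound 4.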